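Series notes: para substituent on the pendant phenyl ring

The source may report more compounds than this note shows. Statements on the series, on what has been measured and on what is new or still open speak of the compounds shown alone.

The shared core carries an acrylamide bearing a bromine on the terminal carbon at one end and a substituted phenyl at the other. Compound 1 `C=C(Br)C(=O)Nc1cccc(-c2cn3nc(-c4ccc(OC)c(OC)c4)sc3n2)c1` carries a 3,4-dimethoxyphenyl there; compound 2 `C=C(Br)C(=O)Nc1cccc(-c2cn3nc(-c4ccc(OCC)cc4)sc3n2)c1` carries a 4-ethoxyphenyl; compound 3 `COc1cccc(-c2nn3cc(-c4cccc(N)c4)nc3s2)c1` has the 3-methoxyphenyl and lacks the acrylamide altogether, keeping a free amine. In a functional assay on FM3A cells (Mus musculus) for inhibition, read by cell counting, with a stated time of 2 days (on this read-out lower numbers stand for stronger inhibition and higher numbers for weaker inhibition), compound 1 gives 110 nM, compound 2 gives 1100 nM and compound 3 gives 29000 nM. Going by the values given here, the one step on record, a 10-fold higher number from compound 1 to compound 2 (1.00 log units; beyond the scatter), shows that a change on this phenyl alone can move the number a good way. Compound 2 thus stands second highest of the three, with compound 1 nearest and compound 3 furthest.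

Compound 4 `C=C(Br)C(=O)Nc1cccc(-c2cn3nc(-c4ccc(C)cc4)sc3n2)c1` is the next step from compound 2, with methyl in place of ethoxy on an aromatic carbon. Among the compounds with values here, no measured step removes the oxygen at this position, so the only guide is the size of the change from compound 1 to compound 2. The expectation is a weaker or unchanged number, with an estimated step of a 1.8-fold higher number from compound 2 to compound 4 (0.26 log units; within the scatter). Compound 4 is estimated at 2000 nM, within 500 nM to 8000 nM.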

Compound 4, half-maximal inhibitory concentration: 1200 nM
Compound 4: the middle estimate sits 1.7-fold (0.22 log units) above what was measured, and the stated range covers the measured number.
By their numbers in this assay, from the lowest: compound 1; then compounds 2 and 4 (each within the scatter of the next); then compound 3.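

In this assay, a 1.1-fold higher number from compound 2 to compound 4 (0.04 log units; within the scatter) lies within the scatter, so ethoxy and methyl cannot be told apart at this position, and the oxygen of the ethoxy is not needed to hold the number seen with compound 2. By contrast, an 11-fold higher number from compound 1 to compound 4 (1.04 log units; beyond the scatter) lies beyond the scatter, so the distance from the 3,4-dimethoxyphenyl holds with methyl as it does with ethoxy. No evidence at hand gives a reason for either step.

The compounds shown leave open which of the two methoxy groups of the 3,4-dimethoxyphenyl accounts for that distance. They also leave open how an amine, a carboxylic acid or a longer chain such as butoxy would read in place of the methyl on the shared core.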